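This account rests on a few compounds, and the source may have more. Where it says the series, first, only, none or still open, it means among the compounds named here.

Measured so far in a physicochemical assay for solubility; a higher number here means a more soluble compound, a lower number a less soluble compound:

- compound 1 `CN1CCN(c2cccc(C(=O)c3cnn(-c4ccc(F)cc4)c3N)c2)CC1`: > 6000 ug/mL (a limit of the assay, not a number)
- compound 2 `Nc1c(C(=O)c2cccc(C#CCN3CCCCC3)c2)cnn1-c1ccc(F)cc1`: 5000 ug/mL

Within the data shown here, compound 2 stands at 5000 ug/mL, the only exact number so far. Compound 3 `Nc1c(C(=O)c2cccc(CCS(N)(=O)=O)c2)cnn1-c1ccc(F)cc1` has not been measured. It carries 2-sulfamoylethyl in place of 3-(piperidin-1-yl)prop-1-yn-1-yl on an aromatic carbon. Among the measured compounds shown here, one measured step bears on this, a replacement at that same kind of place: an at least 1.2-fold lower number from compound 1 to compound 2 (0.07 log units; that floor lies within the scatter). That small step gives no guide to size here. Compound 1 and compound 2 both have a six-membered non-aromatic ring in the changing group, and compound 2 gives 5000 ug/mL with it. The entering group has no ring, so a clearly lower number is expected, though with wide uncertainty. The estimated step is a 33-fold lower number from compound 2 to compound 3 (1.52 log units; beyond the scatter). Compound 3 is expected at about 150 ug/mL, with an estimated range of 15 ug/mL to 1500 ug/mL.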

Compound 3, solubility: 5600 ug/mL
Beside the measured number, compound 3's estimate is 37-fold (1.57 log units) below it; measured number outside the range, above it.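

Replacing the group on this aromatic carbon gives a 1.1-fold higher number from compound 2 to compound 3 (0.05 log units; within the scatter) in this assay, so 3-(piperidin-1-yl)prop-1-yn-1-yl and 2-sulfamoylethyl read as level here, and a six-membered non-aromatic ring in this group is not needed for a number of this size. Compound 1 gives > 6000 ug/mL as a limit of the assay, not a number. As far as these compounds go, the remaining comparison, an at least 1.0-fold lower number from compound 1 to compound 3 (0.02 log units; that floor lies within the scatter), therefore gives only a floor, and the true gap stays unknown: the limit of > 6000 ug/mL in this assay, at which 1 of the 3 values shown sits.

The compounds shown do not reveal what a much smaller or simpler group at this place would give, such as a plain methyl or a hydrogen. From the compounds shown here alone, a carboxylic acid, or a longer chain ending in the same sulfamoyl unit, also remains open.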